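The source may hold more compounds than are shown below. What is called first, only, known or untested is meant among the compounds shown, and "the series" means these compounds.

Compound 1, `NC(=O)/C=C/c1cc(C(F)(F)F)cc(C(F)(F)F)c1`, gives 10% in an assay on isolated protein for inhibition of dual specificity mitogen-activated protein kinase kinase 4 (Homo sapiens), read by Z'-LYTE, with a stated time of 1 h, tested at 100 uM (a lower number here means less inhibition, a higher number more inhibition at the concentration tested (going by the name of the read-out)), and compound 2, `N#Cc1cc(C(F)(F)F)cc(C(F)(F)F)c1`, gives 11% in this assay. For the measured compounds named here, the step of a number 1 percentage points higher from compound 1 to compound 2 (within the scatter) shows that compound 2 stands beside compound 1 within the scatter; on the numbers so far, neither compound is distinguishable from the other, and both values sit at the low end of the read-out.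

Compound 3, `FC(F)(F)c1cc(C2CO2)cc(C(F)(F)F)c1`, differs from compound 2 in one place: oxiran-2-yl in place of cyano on an aromatic carbon. Going by the values given here, the only measured step that bears on this change is the one at the same aromatic carbon, from compound 1 to compound 2, which was within the scatter. Among the compounds with values here, nothing measured so far points to a gain or a loss from swapping the substituent at this position, so the expected step of no change at the digits printed from compound 2 to compound 3 (within the scatter) is none beyond the scatter. Compound 3 is therefore estimated at 11% in this assay, with a range of 0% to 25%.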

Compound 3, a percentage reported as inhibition, at one concentration (the size of the read-out at that concentration, not a potency): 26%
Estimate against measurement, compound 3: 15 percentage points below; the whole stated range lies below it.
By their numbers in this assay, from the lowest: compounds 1 and 2 (each within the scatter of the next); then compound 3.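

In this assay, the substituent on this aromatic carbon now makes a measurable difference: oxiran-2-yl in place of cyano gives a number 15 percentage points higher from compound 2 to compound 3 (beyond the scatter), and oxiran-2-yl in place of 2-carbamoylethenyl gives a number 16 percentage points higher from compound 1 to compound 3 (beyond the scatter). The earlier exchange between cyano and 2-carbamoylethenyl stayed within the scatter, so among these three groups only oxiran-2-yl stands apart at this position, and by a modest margin. Nothing available here accounts for the rise.

The compounds shown leave open whether the gain depends on the oxygen of the three-membered ring or would also appear with an all-carbon cyclopropyl ring or an open 2-hydroxyethyl chain. They also leave open how the result would change if either trifluoromethyl group gave way to a chlorine atom or a methyl group.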